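The source may report more compounds than this note shows. Statements on the series, on what has been measured and on what is new or still open speak of the compounds shown alone.

Measured compounds in a functional assay on DU-145 cells (Homo sapiens) for cytotoxicity, read by MTT assay, with a stated time of 48 h; a lower number here means a stronger inhibitor, a higher number a weaker inhibitor:
compound 1 `COc1cc(-c2cc(COCc3cn(Cc4cc(-c5ccccc5)cnc4Cl)nn3)on2)cc(OC)c1OC`, 78500 nM
compound 2 `COc1cc(COCc2cn(Cc3cc(-c4ccc(C)cc4)cnc3Cl)nn2)cc(OC)c1OC`, 37000 nM
compound 3 `COc1cc(C2CC(COCc3cn(Cc4cc(-c5ccc(F)cc5)cnc4Cl)nn3)ON2C=O)cc(OC)c1OC`, 32800 nM

Compound 1 has the highest number of the three; compound 2 lies beyond the scatter below it and compound 3 further still, so compound 1 is the weakest inhibitor measured here. Compound 4 `COc1cc(-c2cc(COCc3cn(Cc4cc(C)cnc4Cl)nn3)on2)cc(OC)c1OC` differs from compound 1 by methyl in place of phenyl on an aromatic carbon. Among the measured compounds shown here, no measured pair shows this change on its own, and compounds 2 and 3 differ from compound 1 in more than one place, so their values give no single-change comparison for the step. The expected step is a 1.0-fold higher number from compound 1 to compound 4 (0.01 log units; within the scatter), none beyond the usual scatter, with wide uncertainty. Compound 4 is expected near 80000 nM, between 30000 nM and 200000 nM.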

Compound 4, half-maximal inhibitory concentration: 39800 nM
For compound 4 the middle estimate is 2.0-fold (0.30 log units) above the measured one; the range from low to high includes it.
By their numbers in this assay, from the lowest: compounds 3, 2, 4 and 1 (each within the scatter of the next, the first and the last beyond it).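

In this assay, methyl in place of phenyl on the aromatic carbon para to the chloro group gives a 2.0-fold lower number from compound 1 to compound 4 (0.29 log units; within the scatter). Among the compounds shown here, this is the first direct reading at this position: with the shared core unchanged, the six-membered aromatic ring of carbon only can give way to a single carbon without a change beyond the scatter. No measurement on hand accounts for this result.

As far as these compounds go, whether an amine, a carboxylic acid or a longer alkyl chain on this carbon would shift the number beyond the scatter stays open. From the compounds shown here alone, whether the same tolerance holds on other cores also stays open.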